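Swapping cyclohexyl for phenyl on the aromatic nitrogen

The compounds below may be only part of what the source reports. "The series", "measured", "known", "first", "only" and "open" are said of these compounds alone.

Measured in a functional assay on NCI-H1975 cells (Homo sapiens) for cytotoxicity, read by MTT assay, with a stated time of 72 h; on this read-out higher numbers stand for weaker inhibition and lower numbers for stronger inhibition:
- compound 1 `CC(C)n1c(Nc2ccccc2)nc2cnc(Nc3ccc(N4CCN(C)CC4)cc3)nc21`: 960 nM
- compound 2 `CN1CCN(c2ccc(Nc3ncc4nc(Nc5ccccc5)n(C5CCCCC5)c4n3)cc2)CC1`: 390 nM

Of these two compounds, compound 2 has the lower number, 390 nM, and so the stronger inhibition. The next compound, compound 3 `CN1CCN(c2ccc(Nc3ncc4nc(Nc5ccccc5)n(-c5ccccc5)c4n3)cc2)CC1`, has phenyl in place of cyclohexyl on an aromatic nitrogen.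

For the measured compounds named here, only one measured step bears on this change. It is a modest one on the same kind of nitrogen: a 2.5-fold lower number from compound 1 to compound 2 (0.39 log units; beyond the scatter), with cyclohexyl in place of isopropyl. Going by the values given here, no measured compound carries an aromatic ring there, so that step gives only a rough idea of how much this substituent can matter and no clear direction. A shift beyond the usual scatter in this assay is therefore not expected. The expected change is a 1.3-fold higher number from compound 2 to compound 3 (0.11 log units; within the scatter). For compound 3 the estimated value is 500 nM, with an expected range from 170 nM to 1500 nM.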

Compound 3, half-maximal inhibitory concentration: 1830 nM
Compound 3: the middle estimate sits 3.7-fold (0.56 log units) below what was measured; measured number outside the range, above it.
By their numbers in this assay, from the lowest: compound 2; then compounds 1 and 3 (each within the scatter of the next).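

In this assay this position responds to more than the size of the group: cyclohexyl and phenyl have the same count of heavy atoms and differ in that only phenyl is aromatic, yet that swap gives a 4.7-fold higher number from compound 2 to compound 3 (0.67 log units; beyond the scatter) and costs more than the earlier step from isopropyl to cyclohexyl gained. Phenyl and isopropyl, though very different in shape, are not told apart (a 1.9-fold higher number from compound 1 to compound 3 (0.28 log units; within the scatter)), so among these three groups only cyclohexyl stands out, and compound 2 remains the most potent. Nothing measured here explains this difference.

From the compounds shown here alone, it remains open whether the benefit belongs to cyclohexyl alone or extends to other non-aromatic rings, such as cyclopentyl or a tetrahydropyranyl ring containing oxygen. A benzyl group would also show whether phenyl behaves differently when set one carbon further from the aromatic nitrogen.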